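From ethylamino to allylamino: compound 1 and compound 4

This account rests on a few compounds, and the source may have more. Where it says the series, first, only, none or still open, it means among the compounds named here.

Measured in a functional assay on MOLT-4 cells (Homo sapiens) for cytotoxicity, read by MTT assay, with a stated time of 48 h (a lower number here means a stronger inhibitor, a higher number a weaker inhibitor), so far:
- compound 1 `CCNc1n[n+]([O-])c2ccccc2[n+]1[O-]` gives 3300 nM
- compound 2 `COc1ccc(Nc2n[n+]([O-])c3ccccc3[n+]2[O-])cc1` gives 600 nM
- compound 3 `Cc1ccc(Nc2n[n+]([O-])c3ccccc3[n+]2[O-])cc1` gives 1100 nM

Compound 1 has the highest number of the three, and its gaps to compound 2 and compound 3 lie beyond the scatter. Compound 4 `C=CCNc1n[n+]([O-])c2ccccc2[n+]1[O-]`, not yet measured, differs from compound 1 by vinyl in place of methyl on a saturated chain carbon bound to a nitrogen on an aromatic ring, which reads as ethyl to allyl. Going by the values given here, no measured step touches this place. The only one available, a 1.8-fold higher number from compound 2 to compound 3 (0.26 log units; within the scatter), is methyl in place of methoxy on an aromatic carbon and bears on the change only loosely. No change beyond the scatter is therefore expected in this assay. The expected step is a 1.2-fold lower number from compound 1 to compound 4 (0.07 log units; within the scatter) and would stay within the scatter. For compound 4 the estimate is 2800 nM, with an expected range from 1300 nM to 6000 nM.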

Compound 4, half-maximal inhibitory concentration: 3000 nM
Beside the measured number, compound 4's estimate is 1.1-fold (0.03 log units) below it, and the stated range covers the measured number.
By their numbers in this assay, from the lowest: compounds 2 and 3 (each within the scatter of the next); then compounds 4 and 1 (each within the scatter of the next).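

In this assay, the step at this place gives a 1.1-fold lower number from compound 1 to compound 4 (0.04 log units; within the scatter). Going by these compounds alone, it is the first measured change on a saturated chain carbon bound to a nitrogen on an aromatic ring, and vinyl in place of methyl there stays within the scatter. No evidence is available to account for this result.

The compounds shown leave open whether propyl, the saturated chain matching allyl, would read like allyl. They also leave open whether a longer chain, or an amine or a carboxylic acid at the end of the chain, would move the number beyond the scatter.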